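The source may report more compounds than this note shows. Statements on the series, on what has been measured and on what is new or still open speak of the compounds shown alone.

Measured compounds:
- compound 1, `COc1cc(Cl)cc(-c2nn(-c3cccc(NC(=O)c4ccc(Cl)c(Cl)c4)c3)cc2-c2ccncc2)c1`: 53.7%
- compound 2, `O=C(Nc1cccc(-n2cc(-c3ccncc3)c(-c3cc(O)cc(Cl)c3)n2)c1)Nc1ccc(Cl)c(C(F)(F)F)c1`: -16%

In a functional assay on NCI-H522 cells (Homo sapiens) for inhibition, read by sulforhodamine B assay, with a stated time of 48 h, tested at 10 uM (on this read-out higher numbers stand for a weaker effect at the one concentration tested and lower numbers for a stronger effect), compound 2 gives -16%, the lowest of the two numbers recorded, and compound 1 gives 53.7%, a number that lies well beyond the scatter above it. The two compounds differ in more than one place, so no single change can be read off from that gap.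

The step from compound 2 to compound 3, `COc1cc(Cl)cc(-c2nn(-c3cccc(NC(=O)Nc4ccc(Cl)c(C(F)(F)F)c4)c3)cc2-c2ccncc2)c1`, is a single change: methyl in place of hydrogen on an oxygen on an aromatic ring. Compound 3 has not yet been tested in this assay. Among the measured compounds shown here, no measured pair shows this change on its own, so its direction is open. Compound 1, which carries the methoxy group, gives 53.7%, but it also differs from compound 2 elsewhere, so that number is only a loose pointer. A step of moderate size toward a weaker effect is expected, a number 24 percentage points higher from compound 2 to compound 3 (beyond the scatter), though a step within the scatter is also plausible. For compound 3 the estimate is 8%, with a range from -20% to 45%.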

Compound 3, a percentage reported as activity, at one concentration (the size of the read-out at that concentration, not a potency): -10.4%
Compound 3: middle estimate off by 18.4 percentage points, on the high side; measured number inside the range.
By their numbers in this assay, from the lowest: compounds 2 and 3 (each within the scatter of the next); then compound 1.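

In this assay the change from hydroxy to methoxy on the aromatic ring gives a number 5.6 percentage points higher from compound 2 to compound 3 (within the scatter) and so does not separate the two compounds at this concentration, which shows that this oxygen can carry either hydrogen or methyl without a readable shift in this urea-bearing pair. Compound 3 also places the large gap elsewhere: with the methoxy group held constant, (4-chloro-3-(trifluoromethyl)phenyl)amino in place of 3,4-dichlorophenyl on a carbonyl carbon gives a number 64.1 percentage points lower from compound 1 to compound 3 (beyond the scatter), so in this set the change on the carbonyl carbon, not the change on the oxygen, goes with the large step. Nothing measured here gives a reason for either step.

On these data alone, whether a longer chain such as ethoxy on this oxygen, or an amine in place of it, would also leave the read-out within the scatter remains open. Also open, as far as these compounds go, is whether hydroxy and methoxy would stay this close with the 3,4-dichlorophenyl group on the carbonyl carbon, and whether compounds 2 and 3 would still match at concentrations other than the single one tested.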